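The compounds below may be only part of what the source reports. "The series", "measured", "known", "first", "only" and "open" are said of these compounds alone.

Measured so far:
Compound 1, `CCOC(=O)c1cscc1-c1ccc(OC)c(OC)c1`, gives 3% in an assay on isolated protein for inhibition of protein kinase C zeta type (Homo sapiens), with stated times of 1 h and 2.5 min, tested at 30 uM; a lower number here means less inhibition, a higher number more inhibition at the concentration tested (going by the name of the read-out).
Compound 2, `CCOC(=O)c1c(-c2ccc(OC)c(OC)c2)csc1NC`, gives 32% in this assay.

Going by the values given here, compound 2 is the higher of the two numbers in this assay; the only other compound, compound 1, sits a number 29 percentage points higher from compound 1 to compound 2 (beyond the scatter) below it, and that step came with methylamino in place of hydrogen on an aromatic carbon.

Compound 3, `CCOC(=O)c1c(-c2ccc(OC)c(OC)c2)csc1N(C)C`, is not yet measured in this assay. Against compound 2 it differs by methyl in place of hydrogen on a nitrogen on an aromatic ring, the same difference read one bond further out being methylamino to dimethylamino.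

Among the compounds with values here, no measured step touches this change. Within the data shown here, the one step known, from compound 1 to compound 2, concerns the arrival of the methylamino group itself, not a further methyl on its nitrogen, so it gives no direction for compound 3. In the absence of a bearing step, the expectation for compound 3 in this assay is a step of a number 2 percentage points lower from compound 2 to compound 3 (within the scatter), that is, no movement beyond the scatter in either direction, with wide uncertainty. Compound 3 is therefore estimated at 30% in this assay, with a range of 5% to 60%.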

Compound 3, a percentage reported as inhibition, at one concentration (the size of the read-out at that concentration, not a potency): 60%
Beside the measured number, compound 3's estimate is 30 percentage points below it, within the range that was stated.
By their numbers in this assay, from the lowest: compound 1; then compound 2; then compound 3.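

In this assay, the second methyl on the nitrogen does not end the trend set by methylamino: the step is a number 28 percentage points higher from compound 2 to compound 3 (beyond the scatter), so this position still responds to a change made on the nitrogen itself, and the hydrogen on that nitrogen is not needed for the higher number seen with compound 3. Taken as one change on the aromatic carbon, dimethylamino in place of hydrogen gives a number 57 percentage points higher from compound 1 to compound 3 (beyond the scatter), and among these three compounds the read-out rises with each methyl added, with no compound going against that order. Nothing measured on these compounds speaks to why the number rises.

As far as these compounds go, whether the rise continues with larger groups on the nitrogen, such as diethylamino or a pyrrolidine ring, or survives a carbonyl there, as in acetylamino, remains open. Also open, from the compounds shown here alone, is how much the result depends on the ethyl ester held constant in all three compounds, for example with a carboxylic acid or a primary amide in its place, and each reading here is still a single-concentration inhibition rather than a potency.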